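This account rests on a few compounds, and the source may have more. Where it says the series, first, only, none or still open, it means among the compounds named here.

Measured so far in an ADME assay on HEL cells (Homo sapiens) for cytotoxicity; a higher number here means that more compound is tolerated, a lower number that less compound is tolerated:
- compound 1 `COc1ccc(/C=N/NC(=O)COc2cccc3ccccc23)cc1OC` gives 52.6 ug/mL
- compound 2 `O=C(COc1cccc2ccccc12)N/N=C/c1ccc([N+](=O)[O-])cc1` gives 14.2 ug/mL
- compound 3 `O=C(COc1cccc2ccccc12)N/N=C/c1ccccc1Cl` gives 62.7 ug/mL

All three share a core built around a hydrazide linked to an aryl group through a carbon with a double bond to nitrogen; they differ only in that aryl group. On the numbers shown, compound 3 stands at the highest of the three values, but its nearest neighbour, compound 1, lies within the usual scatter of it, so no order between those two can be claimed. Compound 2 stands clearly lower, beyond the scatter of compound 3.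

The next compound, compound 4 `COc1ccc(/C=N/NC(=O)COc2cccc3ccccc23)cc1`, is obtained from compound 3 by one change:

4-methoxyphenyl in place of 2-chlorophenyl on a carbon with a double bond to nitrogen

For the measured compounds named here, no measured pair of compounds shows this particular change, so the size of the step cannot be read from the data. Compound 1, which also carries a methoxy-bearing aryl group, gives a value close to that of compound 3, and the change of 4-methoxyphenyl in place of 2-chlorophenyl is small in what it adds. Compound 4 is therefore expected to sit near compound 3, with a step of a 1.1-fold lower number from compound 3 to compound 4 (0.06 log units; within the scatter) not beyond the scatter in either direction. The estimate for compound 4 in this assay is 55 ug/mL, with a range from 30 ug/mL to 110 ug/mL.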

Compound 4, half-maximal cytotoxic concentration: 100 ug/mL
For compound 4 the middle estimate is 1.8-fold (0.26 log units) below the measured one, within the range that was stated.
By their numbers in this assay, from the lowest: compound 2; then compounds 1, 3 and 4 (each within the scatter of the next).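

In this assay, the exchange of 2-chlorophenyl for 4-methoxyphenyl on a carbon with a double bond to nitrogen gives a 1.6-fold higher number from compound 3 to compound 4 (0.20 log units; within the scatter) and so does not separate these two aryl groups, while hydrogen in place of methoxy on an aromatic carbon gives a 1.9-fold higher number from compound 1 to compound 4 (0.28 log units; within the scatter) and likewise leaves the two compounds unseparated. For the compounds shown here, the clear result is methoxy in place of nitro on an aromatic carbon, which gives a 7.0-fold higher number from compound 2 to compound 4 (0.85 log units; beyond the scatter) and is the first single-place comparison showing that one substituent on this aryl group can shift the tolerated concentration beyond the scatter, with nitro the only group here that stands apart from the others. No measured evidence is available to explain this difference.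

The compounds shown leave open whether the lower number of compound 2 is particular to nitro or would also appear with an amine or a carboxylic acid on the same aromatic carbon. They also leave open whether a longer chain, such as ethoxy or propoxy in place of methoxy, would stay within the scatter of compound 4 in this assay or move beyond it.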